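This account rests on a few compounds, and the source may have more. Where it says the series, first, only, none or still open, it means among the compounds named here.

The study centres on a shared core carried by compound 2 `CCOC(=O)c1c(Nc2ccc(I)cc2F)sc2c1CC(C)(C)CNC2=O` and compound 3 `CCOC(=O)c1c(Nc2ccc(I)cc2Cl)sc2c1CC(C)(C)CNC2=O`. In a functional assay on HT-29 cells (Homo sapiens) for antiproliferative activity (a lower number here means a stronger inhibitor, a higher number a weaker inhibitor), compound 2 gives "not determined" (no result reported), and compound 3 gives "not determined" (no result reported), so neither stands at any number in this assay. The only measured point in the set is compound 1 `CC1(C)CNC(=O)c2sc(Nc3ccc(I)cc3Cl)c(C(=O)NCC[C@@H](O)CO)c2C1`, which in this assay gives 12100 nM. Among the compounds with values here, no single-place step between measured compounds is available, so nothing can be said about the size of any measured change.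

The move from compound 2 to compound 4 `CC1(C)CNC(=O)c2sc(Nc3ccc(I)cc3F)c(C(=O)NOC[C@H](O)CO)c2C1` replaces ((2,3-dihydroxypropoxy)amino in place of ethoxy on a carbonyl carbon). The change is a large one in what is counted, and the other compounds offer no direct comparison for it. What can be said is that compound 4 resembles compound 1 in carrying a carbamoyl group bearing hydroxyl groups on the carbonyl carbon, while differing in the halogen on the aniline ring and in the linker of the carbamoyl group.

On that basis compound 4 is expected to sit in the weak range in this assay, an estimate of 9000 nM with a range from 2500 nM to 35000 nM, because compound 1 gives 12100 nM and compound 2 gives no number to anchor a step.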

Compound 4, half-maximal inhibitory concentration: 1580 nM
For compound 4 the middle estimate is 5.7-fold (0.76 log units) above the measured one; the whole stated range lies above it.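

No new step can be read from compound 4: compound 2 carries no number in this assay to compare with, and compound 1 differs from compound 4 in more than one place. Nothing measured here accounts for the value of compound 4. The compounds shown leave open how far the change from ethoxycarbonyl to (2,3-dihydroxypropoxy)carbamoyl alone shifts activity.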